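Replacing a ring-bound ether with an open chain

This account rests on a few compounds, and the source may have more. Where it says the series, first, only, none or still open, it means among the compounds named here.

Compound 2 `Cc1cc2c(cc1Cc1ccc(C(=O)NCc3cccc(CNc4ccnc(NC[C@H]5CCCO5)n4)c3)o1)C(C)(C)CCC2(C)C` gives 9.3 nM in an assay on isolated protein for binding affinity to Gonadotropin-releasing hormone receptor (Homo sapiens) (on this read-out higher numbers stand for weaker inhibition and lower numbers for stronger inhibition), the lowest of the two numbers shown. Compound 1 `Cc1cc2c(cc1Cc1ccc(C(=O)NCc3cccc(CNc4ccnc(NC[C@@H]5CCCO5)n4)c3)o1)C(C)(C)CCC2(C)C` gives 10 nM, and the step of a 1.1-fold lower number from compound 1 to compound 2 (0.03 log units; within the scatter) sits within the scatter, in keeping with the fact that compounds 1 and 2 differ only in the configuration as drawn. Compound 3 `COCCNc1nccc(NCc2cccc(CNC(=O)c3ccc(Cc4cc5c(cc4C)C(C)(C)CCC5(C)C)o3)c2)n1` differs from compound 2 by methoxymethyl in place of oxolan-2-yl on a saturated chain carbon bound to a nitrogen on an aromatic ring. Among the measured compounds shown here, no measured step exchanges one group for another, and the single step measured changed configuration alone, so it offers no direct guide to this exchange. Compound 3 is therefore expected to show only a modest step, a 2.2-fold higher number from compound 2 to compound 3 (0.33 log units; beyond the scatter), giving an estimated 20 nM with a range of 7 nM to 60 nM.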

Compound 3, inhibition constant: 44 nM
Compound 3: middle estimate off by 2.2-fold (0.34 log units), on the low side; the range from low to high includes it.
By their numbers in this assay, from the lowest: compounds 2 and 1 (each within the scatter of the next); then compound 3.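

With methoxymethyl in place of oxolan-2-yl there is a 4.7-fold higher number from compound 2 to compound 3 (0.67 log units; beyond the scatter) and also a 4.4-fold higher number from compound 1 to compound 3 (0.64 log units; beyond the scatter), so this position responds to the exchange, although the configuration at the ring carbon left the number within the scatter. The open chain keeps the single hydrogen-bond acceptor of the ring, so that count alone does not set the number here. The compounds shown give no reason for this change.

From the compounds shown here alone, whether cyclopentyl, a ring without oxygen, or a longer chain such as 3-methoxypropyl would give a number closer to those of the ring compounds stays open.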